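A few compounds are considered here, and "the series" means these few. Any claim that something is new, unique, unknown or untested is made for them only; others in the source may bear on it.

Measured so far in a functional assay on cells (T-cell, Mus musculus) for inhibition; on this read-out lower numbers stand for stronger inhibition and higher numbers for weaker inhibition:

- compound 1, `O=C(Nc1ccccc1)C(=O)Nc1ccc2c(c1)COC2=O`: 36100 nM
- compound 2, `O=C(Nc1ccc(F)cc1)C(=O)Nc1ccc2c(c1)COC2=O`: 570 nM

For the measured compounds named here, compound 2 holds the lowest of the two numbers so far, and the nearest point of comparison is compound 1, which lies a long way above it: the step of a 63-fold lower number from compound 1 to compound 2 (1.80 log units; beyond the scatter) came with fluoro in place of hydrogen on an aromatic carbon and lies well beyond the scatter.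

Compound 3, `O=C(Nc1ccc(Cl)cc1)C(=O)Nc1ccc2c(c1)COC2=O`, is built on the same core as compound 2. The change is chloro in place of fluoro on an aromatic carbon, sitting on an aromatic carbon of a six-membered aromatic ring of carbon only, para to a large group.

Going by the values given here, only one measured step exists here, and it concerns a different swap: hydrogen to fluoro at this position. Among the compounds with values here, no measured pair shows chloro in place of fluoro, so the size of the coming step is uncertain. Since the step of a 63-fold lower number from compound 1 to compound 2 (1.80 log units; beyond the scatter) shows this position to be sensitive, some movement is plausible, but the direction is not fixed by the data. Compound 3 is estimated at 400 nM (range 100 nM to 1600 nM), which would be an expected step of a 1.4-fold lower number from compound 2 to compound 3 (0.15 log units; within the scatter) from compound 2, within the scatter.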

Compound 3, half-maximal inhibitory concentration: 2240 nM
For compound 3 the middle estimate is 5.6-fold (0.75 log units) below the measured one; the whole stated range lies below it.
By their numbers in this assay, from the lowest: compound 2; then compound 3; then compound 1.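

In this assay, the ring carbon para to a large group does not treat the two halogens alike: chloro in place of fluoro gives a 3.9-fold higher number from compound 2 to compound 3 (0.59 log units; beyond the scatter) and so sets them apart, which the earlier pair could not show. Chloro in place of hydrogen still gives a 16-fold lower number from compound 1 to compound 3 (1.21 log units; beyond the scatter) on the same ring, so the gain seen earlier does not belong to fluoro alone, though fluoro gives the lowest number of the three and compound 1, with hydrogen at this spot, gives the highest. Nothing at hand explains why the two halogens differ at this carbon.

On these data alone, with only hydrogen, fluoro and chloro to compare, it remains open whether other groups here, such as bromo, methyl, methoxy, an amine or a carboxylic acid, would match fluoro, fall back towards compound 1, or go lower still. As far as these compounds go, it is also open whether the order of these three would hold with the same groups at another carbon of this ring, or with a change elsewhere on the shared core.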